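A few compounds are considered here, and "the series" means these few. Any claim that something is new, unique, unknown or untested is made for them only; others in the source may bear on it.

Measured compounds:
- compound 1 `CC1(C)[C@@H]2CC[C@@]1(CS(=O)(=O)N1CCN(c3ncccc3C(F)(F)F)CC1)C(=O)C2`: > 31600 nM
- compound 2 `CC1(C)[C@@H]2CC[C@@]1(CS(=O)(=O)N1CCN(c3ccc(C(F)(F)F)c(Cl)n3)CC1)C(=O)C2`: 251 nM
- compound 3 `CC1(C)[C@@H]2CC[C@@]1(CS(=O)(=O)N1CCN(c3nc(Cl)c(C(F)(F)F)cc3Cl)CC1)C(=O)C2`: 316 nM

All three share the same core and differ only in the aromatic ring attached to the amine nitrogen in a ring. In a functional assay on CHO-K1 cells for antagonist activity at C-X-C chemokine receptor type 3 (Homo sapiens), read by FLIPR and calcium flux (on this read-out higher numbers stand for weaker inhibition and lower numbers for stronger inhibition), compound 1 gives > 31600 nM, which is a limit of the assay and not a measured number. Compound 1 therefore stands at the limit of > 31600 nM in this assay, at which 1 of the 3 values shown sits, with no inhibition that the assay could put a value on. Among the measured compounds shown here, compound 2 gives 251 nM in this assay, and compound 3 gives 316 nM; the one measured step, a 1.3-fold higher number from compound 2 to compound 3 (0.10 log units; within the scatter), shows that a chloro in place of hydrogen on an aromatic carbon changes little.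

Compound 4 `CC1(C)[C@@H]2CC[C@@]1(CS(=O)(=O)N1CCN(c3ncc(Br)cn3)CC1)C(=O)C2` has not been measured yet. It differs from compound 1 by 5-bromopyrimidin-2-yl in place of 3-(trifluoromethyl)pyridin-2-yl on an amine nitrogen in a ring. For the measured compounds named here, no measured step covers this kind of ring exchange, so the only guide is that compound 2 and compound 3, each carrying a different substituted aromatic ring on the same nitrogen, give numbers while compound 1 gives only a limit. A fall from the limit of compound 1 is therefore possible but uncertain, and the expected step of an at least 10-fold lower number from compound 1 to compound 4 (1.02 log units; beyond the scatter) rests on that thin base. Compound 4 is estimated to give 3000 nM in this assay, within a wide range from 250 nM to 31600 nM.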

Compound 4, half-maximal inhibitory concentration: 631 nM
Estimate against measurement, compound 4: 4.8-fold (0.68 log units) above, within the range that was stated.
By their numbers in this assay, from the lowest: compounds 2, 3 and 4 (each within the scatter of the next, the first and the last beyond it). At a limit, above all of these: compound 1.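

In this assay, exchanging the whole aromatic ring on the amine nitrogen of the shared core gives an at least 50-fold lower number from compound 1 to compound 4 (1.69 log units; beyond the scatter). The earlier step showed only that adding a chloro on an aromatic carbon changes little, whereas this one shows that the choice of ring at this place can move the number a long way, and that compound 4 has a value that could be measured with no trifluoromethyl group on its ring. The true size of the step remains unknown because compound 1 stands at a limit: the limit of > 31600 nM in this assay, at which 1 of the 4 values shown sits.

The exchange alters several things at once, namely the number of ring nitrogens, bromine against trifluoromethyl, and where the substituent sits on the ring, so the compounds shown cannot say which of these accounts for the step. Also open, on these data alone, is how a plain pyrimidin-2-yl ring without bromine, or a pyrimidin-2-yl ring with a nitrile or a methoxy group in place of the bromine, would read in this assay.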